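Lengthening a Methyl to Ethyl on a Silent Core

The compounds below may be only part of what the source reports. "The series", "measured", "known", "first", "only" and "open" are said of these compounds alone.

compound 1 `Cc1nc(C)n2c(S)nncc12` — > 48000 nM
compound 2 `Cc1nc(C)n2c(O)nncc12` — > 48000 nM
compound 3 `Cc1ncc2cnnc(S)n12` — > 48000 nM

Of the compounds shown here, three have been tested in a functional assay for inhibition, with Homo sapiens as the target; on this read-out higher numbers stand for weaker inhibition and lower numbers for stronger inhibition. In this assay compound 1 gives > 48000 nM, which is a limit of the assay rather than a number. Compound 2 likewise gives > 48000 nM, a limit. Compound 3 gives > 48000 nM, again a limit. Since (the limit of > 48000 nM in this assay, at which 3 of the 3 values shown sit), neither step among them can be read: a step that the two limits leave unreadable from compound 1 to compound 2 and a step that the two limits leave unreadable from compound 1 to compound 3 both sit between two limits. Compound 1 therefore stands only at a limit and cannot be placed relative to its neighbours.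

Compound 4 `CCc1nc(C)c2cnnc(S)n12` differs from compound 1 by methyl in place of hydrogen on a saturated chain carbon bound to an aromatic carbon; cut one bond further out, the change reads methyl to ethyl. Among the measured compounds shown here, no measured step touches the same place. The two steps that do exist, hydroxy in place of sulfanyl and hydrogen in place of methyl on an aromatic carbon, are both unreadable, so nothing in them argues for a change beyond the scatter, and the shared core has so far shown no inhibition with either substitution. Compound 4 is therefore expected to show no step beyond the scatter, a step that the limit leaves unreadable from compound 1 to compound 4, with a limit again the likeliest outcome. The estimate for compound 4 is 60000 nM, in the range 20000 nM to 200000 nM.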

Compound 4, half-maximal inhibitory concentration: > 48000 nM
Compound 4: only a limit was reported; the forecaster's own chance of this, stated with the estimate: 85%; the middle value lies beyond the limit too.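

In this assay compound 4 gives > 48000 nM, which is a limit of the assay and not a number. No step can be read between compound 1 and compound 4, because both stand at a limit: the limit of > 48000 nM in this assay, at which 4 of the 4 values shown sit. The compounds shown leave open whether any change to the shared core would give a measurable inhibition.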